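Adding methoxy to a nitro compound in a cell test

This account rests on a few compounds, and the source may have more. Where it says the series, first, only, none or still open, it means among the compounds named here.

Measured so far in an ADME assay on HeLa cells (Homo sapiens) for cytotoxicity, read by crystal violet staining, with a stated time of 72 h; a lower number here means that less compound is tolerated, a higher number that more compound is tolerated:
Compound 1 `COc1cc(-c2noc(C(F)(F)F)n2)ccc1OCCCc1cc(C(=O)N(C)C)no1`: 68000 nM
Compound 2 `CN(C)C(=O)c1cc(CCCOc2ccc(-c3noc(C(F)(F)F)n3)cc2[N+](=O)[O-])on1`: 22500 nM

Of these two, compound 2 has the lower number, so cells tolerate less of it than of compound 1. The next compound, compound 3 `COc1cc(-c2noc(C(F)(F)F)n2)cc([N+](=O)[O-])c1OCCCc1cc(C(=O)N(C)C)no1`, keeps the nitro group of compound 2 and differs from it as follows: methoxy in place of hydrogen on an aromatic carbon. Put simply, this is methoxy in place of hydrogen on an aromatic carbon.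

Among the compounds with values here, only one measured step bears on this change: a 3.0-fold lower number from compound 1 to compound 2 (0.48 log units; beyond the scatter). That step was modest, but it exchanged methoxy for nitro, whereas compound 3 carries both groups. Within the data shown here, no measured pair shows what adding methoxy does while nitro stays, so the guide is only partial. Compound 1, which has methoxy and no nitro, gives 68000 nM, which points to a small upward move in this assay, if any move appears at all. The expected size is a 1.3-fold higher number from compound 2 to compound 3 (0.12 log units; within the scatter). For compound 3 the estimated value is 30000 nM, with an expected range from 12000 nM to 75000 nM.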

Compound 3, half-maximal cytotoxic concentration: 25600 nM
Compound 3: middle estimate off by 1.2-fold (0.07 log units), on the high side, and the stated range covers the measured number.
By their numbers in this assay, from the lowest: compounds 2 and 3 (each within the scatter of the next); then compound 1.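

In this assay, placing methoxy on the ring that already carries nitro, ortho to a large group and meta to both the nitro group and the 5-(trifluoromethyl)-1,2,4-oxadiazol-3-yl group, gives a 1.1-fold higher number from compound 2 to compound 3 (0.06 log units; within the scatter), so this change leaves no readable mark on the number while nitro stays. The second new pair isolates what the earlier exchange of methoxy for nitro could not: with methoxy kept in place, nitro in place of hydrogen on an aromatic carbon gives a 2.7-fold lower number from compound 1 to compound 3 (0.42 log units; beyond the scatter), a modest step of about the same size as a 3.0-fold lower number from compound 1 to compound 2 (0.48 log units; beyond the scatter). Nothing among the data shown accounts for either result.

From the compounds shown here alone, the effect of methoxy on a ring without nitro remains open, since that would need the compound with hydrogen in both places for comparison. Going by these compounds, it is also open whether an amine or a carboxylic acid in place of nitro would keep the lower number seen with compound 2 and compound 3, or return it to the level of compound 1.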